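Triazolylmethyl Thioether Variant of a Diaminopyridine Dinitrile Scaffold

This account rests on a few compounds, and the source may have more. Where it says the series, first, only, none or still open, it means among the compounds named here.

Measured compounds:
compound 1, `N#Cc1c(N)nc(SCC(N)=O)c(C#N)c1-c1ccc(OCC2CC2)cc1`, 8%
compound 2, `C=C(C)COc1ccc(-c2c(C#N)c(N)nc(SCC(N)=O)c2C#N)cc1`, 4%

In an assay on CHO cells for displacement of a labelled ligand from adenosine receptor A3 (Homo sapiens), read by scintillation counting, with a stated time of 120 min, tested at 1 uM (on this read-out higher numbers stand for more inhibition at the one concentration tested (going by the name of the read-out) and lower numbers for less inhibition), compound 1 gives 8%, and compound 2 gives 4%. The two numbers lie within the scatter of each other, a number 4 percentage points lower from compound 1 to compound 2 (within the scatter), so neither compound can be set above the other on this read-out, and both show little displacement at the tested concentration.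

Compound 3, `N#Cc1c(N)nc(SCn2cncn2)c(C#N)c1-c1ccc(OCC2CC2)cc1`, is not yet measured. It differs from compound 1 as follows: 1H-1,2,4-triazol-1-yl in place of carbamoyl on a saturated chain carbon bound to a sulfur. Going by the values given here, the only measured step, from compound 1 to compound 2, alters the group on the oxygen-bound chain carbon, not the sulfur-bound one, so no measured step bears on this change. Since compound 1 and compound 2 both sit low in this assay, compound 3 is expected to stay near that level, with an expected step of a number 1 percentage points higher from compound 1 to compound 3 (within the scatter). The estimate for compound 3 is 9%, within 0% to 25%.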

Compound 3, a percentage reported as inhibition, at one concentration (the size of the read-out at that concentration, not a potency): 1%
Estimate against measurement, compound 3: 8 percentage points above; the measured number falls inside the stated range.
By their numbers in this assay, from the lowest: compounds 3, 2 and 1 (each within the scatter of the next).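

In this assay, exchanging carbamoyl for 1H-1,2,4-triazol-1-yl on a saturated chain carbon bound to a sulfur gives a number 7 percentage points lower from compound 1 to compound 3 (within the scatter). Going by these compounds alone, this is the first look at the sulfur-bound side of the molecule, where the earlier step did not reach, and it shows that the number does not separate from that of compound 1 even though a five-membered aromatic ring with 0 hydrogen-bond donors replaces a group with 1 hydrogen-bond donor. No evidence is available that bears on this result.

The compounds shown leave open whether any group at this place can move the number beyond the scatter, such as a carboxylic acid, an amine or a longer chain. They also leave open whether compound 3 and compound 1 would separate at a concentration other than the one tested.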